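A few compounds are considered here, and "the series" means these few. Any claim that something is new, unique, unknown or untested is made for them only; others in the source may bear on it.

Working notes on the sulfonyl series in a functional assay on BXPC-3 cells (Homo sapiens) for inhibition, read by MTT assay, with a stated time of 7 days; on this read-out lower numbers stand for stronger inhibition and higher numbers for weaker inhibition.

Compound 1 `O=C([C@@H]1CCCN(S(=O)(=O)c2ccc(S(=O)(=O)N3CC[C@@H](O)C3)cc2)C1)N1CCC(F)(F)CC1` gives 330 nM and stands lowest of the three measured numbers. Within the data shown here, compound 2 `CCN(CC)S(=O)(=O)c1ccc(S(=O)(=O)N2CCC[C@@H](C(=O)N3CCC(O)CC3)C2)cc1` gives 4710 nM and compound 3 `CCN(CC)S(=O)(=O)c1ccc(S(=O)(=O)N2CCC[C@@H](C(=O)N3CC[C@H](OC)C3)C2)cc1` gives 6750 nM; the one measured single-point step, a 1.4-fold higher number from compound 2 to compound 3 (0.16 log units; within the scatter), lies within the scatter and concerns the carbonyl end, not the sulfonyl end. Compounds 2 and 3 differ from compound 1 in two places at once, so their gap to compound 1 cannot be assigned to either change.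

Compound 4 `CC(C)CS(=O)(=O)c1ccc(S(=O)(=O)N2CCC[C@@H](C(=O)N3CCC(F)(F)CC3)C2)cc1` keeps the rest of compound 1 and differs only at the sulfonyl sulfur: isobutyl in place of 3-hydroxypyrrolidin-1-yl on a sulfonyl sulfur. Among the measured compounds shown here, no measured step touches this position, so nothing directly bears on it. For the measured compounds named here, the hydrogen-bond donor and acceptor that leave are the only guide, and the weaker numbers of compound 2 and compound 3, which also lack such a donor at the sulfonyl sulfur, suggest a rise is more likely than a fall.

Compound 4 is therefore expected at 1000 nM, within 300 nM to 4000 nM, an expected step of a 3.0-fold higher number from compound 1 to compound 4 (0.48 log units; beyond the scatter) with low confidence.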

Compound 4, half-maximal inhibitory concentration: 311 nM
Estimate against measurement, compound 4: 3.2-fold (0.51 log units) above; the range from low to high includes it.
By their numbers in this assay, from the lowest: compounds 4 and 1 (each within the scatter of the next); then compounds 2 and 3 (each within the scatter of the next).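

In this assay, among these compounds, isobutyl in place of 3-hydroxypyrrolidin-1-yl on a sulfonyl sulfur gives a 1.1-fold lower number from compound 1 to compound 4 (0.03 log units; within the scatter), the first measured step at this position. With the rest of compound 1 kept, the ring, the hydrogen-bond donor and the hydrogen-bond acceptor can all leave this position without a change beyond the scatter, so this pair gives no support to treating such a donor as required there. Nothing available accounts for the two groups reading alike.

The compounds shown do not separate the hydroxyl from the ring, which an unsubstituted pyrrolidin-1-yl on the sulfonyl sulfur would address. On these data alone, how far this tolerance extends also remains open, for example to a longer alkyl chain or a chain ending in a carboxylic acid or an amine.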